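The compounds below may be only part of what the source reports. "The series", "measured", "known", "first", "only" and "open" are said of these compounds alone.

Compound 1 `Cc1cc(C(=O)Nc2ccccc2)nn1Cc1cc(Cl)ccc1OCc1ccccc1` gives in a physicochemical assay for lipophilicity, at pH 7.4 (on this read-out lower numbers stand for lower lipophilicity and higher numbers for higher lipophilicity), only a limit of the assay, > 3.7.
Compound 2 `Cc1cc(C(=O)Nc2c(F)cccc2F)nn1Cc1cc(Cl)ccc1OCc1ccccc1` gives in this assay 3.7.
Compound 3 `Cc1cc(C(=O)NCc2ccccc2)nn1Cc1cc(Cl)ccc1OCc1ccccc1` gives in this assay only a limit of the assay, > 3.7.

Compound 1 thus stands at a limit and not at a number, and because of the limit of > 3.7 in this assay, at which 2 of the 3 values shown sit, its place against compound 2 and compound 3 cannot be read. The three measured steps, a number no higher from compound 1 to compound 2 (the limit leaves the size open), a step that the two limits leave unreadable from compound 1 to compound 3 and a number no lower from compound 2 to compound 3 (the limit leaves the size open), each swap one group on an amide-type nitrogen, and the limits leave every size open. Compound 4 `Cc1cc(NC(=O)C2CCOC2)nn1Cc1cc(Cl)ccc1OCc1ccccc1` is built differently from compound 1: ((oxolan-3-yl)carbonyl)amino in place of phenylcarbamoyl on an aromatic carbon. Among the measured compounds shown here, this exchange removes the phenylcarbamoyl group altogether, and none of the measured steps concerns such a change, so no measured size carries over to it. In this assay the step from compound 1 to compound 4 is expected to run downward, as a number at least 0.70 log units lower from compound 1 to compound 4 (beyond the scatter), with its size uncertain since compound 1 itself is only a limit. Compound 4 is therefore estimated at 3 in this assay, within a range from 2.4 to 3.6.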

Compound 4, distribution coefficient: > 3.7
Compound 4 gave a limit, no number (the forecaster's own chance of this, stated with the estimate: 15%); middle value at least 0.70 log units away from the limit.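

In this assay compound 4 also gives only a limit of the assay, > 3.7. At this aromatic carbon, then, even removing phenylcarbamoyl altogether and putting ((oxolan-3-yl)carbonyl)amino there, with its five-membered non-aromatic ring in place of the six-membered aromatic ring, yields no readable number, which the earlier swaps on the amide-type nitrogen could not show. The one step with a direction is a number no lower from compound 2 to compound 4 (the limit leaves the size open), while the steps to compound 4 from compound 1 and from compound 3 cannot be read, because both ends of each sit at a limit: the limit of > 3.7 in this assay, at which 3 of the 4 values shown sit.

Going by these compounds, how compound 1, compound 3 and compound 4 order among themselves stays open. Also open, on these data alone, is whether an amine or a carboxylic acid on this same aromatic carbon would give a number rather than a limit.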